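This account rests on a few compounds, and the source may have more. Where it says the series, first, only, none or still open, it means among the compounds named here.

In an assay on HT-29 cells for inhibition of Serine-protein kinase ATM (Homo sapiens), read by fluorescence, with a stated time of 1 h (on this read-out lower numbers stand for stronger inhibition and higher numbers for weaker inhibition), compound 1 `CCC(CC)CNc1c(C(N)=O)cnc2ccc(C#N)cc12` gives 820 nM. Compound 2 `C[C@@H](Nc1c(C(=O)O)cnc2ccc(-c3cccnc3)cc12)c1ccc(Cl)cc1` reaches only a limit of the assay, > 30000 nM, so no number is known for it (the limit of > 30000 nM in this assay, at which 1 of the 3 values shown sits). Compound 3 `NC(=O)c1cnc2ccc(-c3cccnc3)cc2c1SC1CCCC1` gives 9700 nM, the higher of the two numbers; the nearest, compound 1, sits clearly lower, beyond the usual scatter. Compound 4 `NC(=O)c1cnc2ccc(-c3cccnc3)cc2c1NCC1CCCCC1` has not yet been measured. It differs from compound 3 in one place: (cyclohexylmethyl)amino in place of cyclopentylsulfanyl on an aromatic carbon. Among the measured compounds shown here, no step between measured compounds matches this change, so its size is uncertain. Compound 4 is expected to inhibit more strongly than compound 3, a step beyond the scatter, because compound 1 gives 820 nM. The expected step is a 6.5-fold lower number from compound 3 to compound 4 (0.81 log units; beyond the scatter). For compound 4 the estimate is 1500 nM, between 400 nM and 6000 nM.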

Compound 4, half-maximal inhibitory concentration: 456 nM
Estimate against measurement, compound 4: 3.3-fold (0.52 log units) above; low and high end bracket the measured number.
By their numbers in this assay, from the lowest: compounds 4 and 1 (each within the scatter of the next); then compound 3. At a limit, above all of these: compound 2.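

In this assay this aromatic carbon, opposite the ring nitrogen, proves sensitive to its substituent: (cyclohexylmethyl)amino in place of cyclopentylsulfanyl gives a 21-fold lower number from compound 3 to compound 4 (1.33 log units; beyond the scatter) on an otherwise unchanged core. The change swaps the sulfur for a nitrogen with its hydrogen-bond donor and also the five-membered ring for a six-membered one, so the step cannot be assigned to either part. Nothing measured here offers a reason for the step.

Still open, from the compounds shown here alone, is whether cyclopentylamino, which pairs the nitrogen link with the five-membered ring, would give a low number as well. The same question applies to (cyclohexylmethyl)sulfanyl, which pairs the sulfur link with the six-membered ring.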